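The compounds below may be only part of what the source reports. "The series", "measured", "known", "first", "only" and "open" are said of these compounds alone.

Measured compounds in a functional assay on SW480 cells (Homo sapiens) for antiproliferative activity, read by MTT assay, with a stated time of 48 h; a lower number here means a stronger inhibitor, a higher number a weaker inhibitor:

Compound 1 `CCCCCCCCCCC(CCO)n1cnc2c(Cl)ncnc21`: 3160 nM
Compound 2 `CCCCCCCCCCC(CCO)n1cnc2c(OC)ncnc21`: 8260 nM
Compound 3 `CCCCCCCCCCCC(CCO)n1cnc2c(Cl)ncnc21`: 5290 nM

Compound 3 is compound 1 with the core changed by methyl in place of hydrogen on a saturated chain carbon, ten or more bonds along the chain from an aromatic nitrogen, and in this assay the step is a 1.7-fold higher number from compound 1 to compound 3 (0.22 log units; within the scatter); compound 3 and compound 1 are therefore read as equivalent here. Compound 2 differs from compound 1 by methoxy in place of chloro on an aromatic carbon, which gives a 2.6-fold higher number from compound 1 to compound 2 (0.42 log units; beyond the scatter).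

Compound 4 `CCCCCCCCCCCC(CCO)n1cnc2c(OC)ncnc21` is not yet measured. It differs from compound 3 by methoxy in place of chloro on an aromatic carbon, the same change as that from compound 1 to compound 2, and the place descriptions match word for word, so the change is taken as the same. Going by the values given here, the only available precedent for this change is the single step of a 2.6-fold higher number from compound 1 to compound 2 (0.42 log units; beyond the scatter), from which a step of comparable size is expected from compound 3 to compound 4, namely a 2.5-fold higher number from compound 3 to compound 4 (0.39 log units; beyond the scatter). Among the compounds with values here, with only one precedent, the range is kept wide. For compound 4 in this assay the estimate is 13000 nM, within 6500 nM to 26000 nM.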

Compound 4, half-maximal inhibitory concentration: 9700 nM
For compound 4 the middle estimate is 1.3-fold (0.13 log units) above the measured one; the range from low to high includes it.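

In this assay, methoxy in place of chloro on an aromatic carbon gives a 1.8-fold higher number from compound 3 to compound 4 (0.26 log units; within the scatter), and this step does not differ from the earlier one, so the change carries across these two cores: the same change on two cores in this assay, a 2.6-fold higher number (0.42 log units; beyond the scatter) from compound 1 to compound 2 and a 1.8-fold higher number (0.26 log units; within the scatter) from compound 3 to compound 4, 1.4-fold (0.15 log units) apart, within the scatter of two such steps

The chain change also reads the same with methoxy as with chloro, giving a 1.2-fold higher number from compound 2 to compound 4 (0.07 log units; within the scatter): the same change on two cores in this assay, a 1.7-fold higher number (0.22 log units; within the scatter) from compound 1 to compound 3 and a 1.2-fold higher number (0.07 log units; within the scatter) from compound 2 to compound 4, 1.4-fold (0.15 log units) apart, within the scatter of two such steps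

Going by these compounds alone, this supports additive behaviour only for these four compounds, whose cores differ by a single methyl on the chain; it does not show that the step holds on other cores, and its exact size stays uncertain, as only the step from compound 1 to compound 2 lies beyond the scatter.

As far as these compounds go, it remains open whether an amine in place of chloro on the same aromatic carbon would give a step of similar size. From the compounds shown here alone, it is also open whether the methoxy step would carry over to a core with a much shorter or longer chain.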